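The source may report more compounds than this note shows. Statements on the series, on what has been measured and on what is new or still open speak of the compounds shown alone.

In a functional assay on U-373MG ATCC cells (Homo sapiens) for antiproliferative activity, read by MTT assay, with a stated time of 72 h (on this read-out higher numbers stand for weaker inhibition and lower numbers for stronger inhibition), compound 1 (`O=C1Nc2c(F)cccc2/C1=C1/Nc2ccccc2C1=O`) gives 45800 nM. Compound 2 (`O=C1Nc2c(Cl)cccc2/C1=C1/Nc2ccccc2C1=O`) gives > 100000 nM, which is a limit and not a number. Compound 3 (`O=C1Nc2ccccc2/C1=C1/Cc2ccccc2C1=O`) gives > 100000 nM, which is also a limit, so it has no measured number to start from. Compound 4 (`O=C1Nc2ccc(Br)cc2/C1=C1/Cc2ccccc2C1=O`) carries bromo in place of hydrogen on an aromatic carbon of compound 3: bromo in place of hydrogen on an aromatic carbon. Within the data shown here, the only measured step that bears on this is an at least 2.1-fold higher number from compound 1 to compound 2 (0.33 log units; beyond the scatter), a swap of chloro for fluoro on the core of compound 1, and it adds no halogen to a hydrogen position. It therefore offers only weak guidance, and a small move toward stronger inhibition in this assay is expected, if any. The expected step is an at least 1.4-fold lower number from compound 3 to compound 4 (0.15 log units; that floor lies within the scatter). The estimate for compound 4 is 70000 nM, with an expected range from 25000 nM to 100000 nM.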

Compound 4, half-maximal inhibitory concentration: 41400 nM
The estimate for compound 4 lay 1.7-fold (0.23 log units) above the measured number; the range from low to high includes it.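

In this assay, bromo in place of hydrogen gives an at least 2.4-fold lower number from compound 3 to compound 4 (0.38 log units; beyond the scatter), the first step shown that puts a halogen on a hydrogen position. On this aromatic carbon, the change turns a limit into a measured number. The true size of the step stays unknown because compound 3 stands only at a limit of the assay: the limit of > 100000 nM in this assay, at which 2 of the 4 values shown sit.

The compounds shown leave open whether this step belongs to bromo in particular. As far as these compounds go, how chloro, a methoxy group or an amine would read at this same place on the core of compound 3 also remains open.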